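Removing a ring fluorine from a thiosemicarbazone

The compounds below may be only part of what the source reports. "The series", "measured", "known", "first", "only" and "open" are said of these compounds alone.

Compound 1 `N/C(=N\NC(=S)N1CCSCC1)c1ccccn1` and compound 2 `N/C(=N\NC(=S)N1CCOCC1)c1ccc(F)cn1` share a core and have both been tested in a functional assay on A-431 cells (Homo sapiens) for cytotoxicity, read by MTT assay, with a stated time of 72 h; on this read-out higher numbers stand for weaker inhibition and lower numbers for stronger inhibition. In this assay compound 1 gives 6700 nM, and compound 2 gives 4000 nM; these two numbers sit within the scatter of each other, so neither compound can be set apart. Compound 3 `N/C(=N\NC(=S)N1CCOCC1)c1ccccn1` is not yet measured. It differs from compound 2 by hydrogen in place of fluoro on an aromatic carbon. Among the measured compounds shown here, with no measured step of this kind to lean on, the change is expected to shift the number from compound 2 to compound 3 by about a 1.3-fold higher number from compound 2 to compound 3 (0.10 log units; within the scatter), nothing beyond the scatter. Compound 3 is therefore estimated at 5000 nM, in a range from 2000 nM to 12000 nM.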

Compound 3, half-maximal inhibitory concentration: 4800 nM
Estimate against measurement, compound 3: 1.0-fold (0.02 log units) above; measured number inside the range.
By their numbers in this assay, from the lowest: compounds 2, 3 and 1 (each within the scatter of the next).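

In this assay, hydrogen in place of fluoro on this aromatic carbon, two atoms from the ring nitrogen, gives a 1.2-fold higher number from compound 2 to compound 3 (0.08 log units; within the scatter) and stays within the scatter, so the two groups cannot be told apart here. Compound 3 also allows a one-place comparison at the thiocarbonyl carbon, where morpholin-4-yl in place of thiomorpholin-4-yl gives a 1.4-fold lower number from compound 1 to compound 3 (0.14 log units; within the scatter) and is again within the scatter. No supporting data bear on either step.

From the compounds shown here alone, whether an amine or a carboxylic acid on this aromatic carbon would move the number beyond the scatter remains open.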